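Swapping the dimethylcarbamoyl group of compound 3 for acetoxymethyl

The source may report more compounds than this note shows. Statements on the series, on what has been measured and on what is new or still open speak of the compounds shown alone.

- compound 1 (`CCCOC(=O)CO/N=C(\C)c1ccc(Cl)cc1`): 14 mg/kg
- compound 2 (`C/C(=N\OCC(=O)OC(C)C)c1ccc(Cl)cc1`): 50 mg/kg
- compound 3 (`C/C(=N\OCC(=O)N(C)C)c1ccc(Cl)cc1`): 120 mg/kg

In a functional assay on the whole organism for inhibition, with Rattus norvegicus as the target, read by paw edema, with stated times of 1 h and 3 h (a lower number here means that less compound is needed, a higher number that more compound is needed for the effect), compound 3 (120 mg/kg) has the highest of the three numbers. Compound 4 (`CC(=O)OCCO/N=C(\C)c1ccc(Cl)cc1`) is not yet measured. It carries acetoxymethyl in place of dimethylcarbamoyl on a saturated chain carbon bound to an oxygen. For the measured compounds named here, two measured steps bear on this change, since both go from an ester to the amide of compound 3: an 8.6-fold higher number from compound 1 to compound 3 (0.93 log units; beyond the scatter) and a 2.4-fold higher number from compound 2 to compound 3 (0.38 log units; beyond the scatter) (both modest). Going by the values given here, compound 4 is an ester again, but no measured compound carries acetoxymethyl, so the parallel is loose. The expected change is therefore a modest fall, a 3.0-fold lower number from compound 3 to compound 4 (0.48 log units; beyond the scatter) (an estimate). Compound 4 is estimated at 40 mg/kg (expected range 15 mg/kg to 110 mg/kg).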

Compound 4, dose for half-maximal effect: 43 mg/kg
Compound 4: middle estimate off by 1.1-fold (0.03 log units), on the low side, within the range that was stated.
By their numbers in this assay, from the lowest: compound 1; then compounds 4 and 2 (each within the scatter of the next); then compound 3.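

In this assay, acetoxymethyl in place of dimethylcarbamoyl on a saturated chain carbon bound to an oxygen gives a 2.8-fold lower number from compound 3 to compound 4 (0.45 log units; beyond the scatter), so a second kind of ester at this place also stands apart from the amide. Acetoxymethyl cannot be told from isopropoxycarbonyl, with a 1.2-fold lower number from compound 2 to compound 4 (0.07 log units; within the scatter), yet it differs from propoxycarbonyl, with a 3.1-fold higher number from compound 1 to compound 4 (0.49 log units; beyond the scatter), so the esters do not form one level. No measurement given here explains these steps. From the compounds shown here alone, whether a carboxylic acid or butoxycarbonyl at this place would give a lower number than compound 1 remains open.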